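This account rests on a few compounds, and the source may have more. Where it says the series, first, only, none or still open, it means among the compounds named here.

Measured so far:
- compound 1 `CCN(CC)C(=O)c1ccccc1OCC1=NCCN1`; in a functional assay for activation of Alpha-1A adrenergic receptor (Homo sapiens), read by calcium flux (a lower number here means that less compound is needed, a higher number that more compound is needed for the effect), compound 1 gives only a limit, < 5020 nM.
- compound 2 `c1csc(-c2ccccc2OCC2=NCCN2)c1`; in this assay compound 2 gives 1 nM.
- compound 3 `Cc1cc(-c2ccccc2OCC2=NCCN2)sn1`; in this assay compound 3 gives 158 nM.

Compound 2 stands at the lowest of the two numbers in this assay; the nearest number belongs to compound 3, reached by a 160-fold higher number from compound 2 to compound 3 (2.20 log units; beyond the scatter). The value of compound 1 is a limit of < 5020 nM in this assay, at which 1 of the 3 values shown sits, and not a number.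

Compound 4 `Cn1nccc1-c1ccccc1OCC1=NCCN1` differs from compound 2 by 1-methyl-1H-pyrazol-5-yl in place of thiophen-2-yl on an aromatic carbon. Within the data shown here, the one measured step at the same place, a 160-fold higher number from compound 2 to compound 3 (2.20 log units; beyond the scatter), also exchanged thiophen-2-yl for one five-membered aromatic ring with 2 hetero atoms, and it was large and upward. On that single step, an upward step of similar size is expected for the present exchange, as a 100-fold higher number from compound 2 to compound 4 (2.00 log units; beyond the scatter), though only compound 3 supports it and the entering ring here is a different one. Compound 4 is therefore expected at 100 nM in this assay, with a range from 10 nM to 1000 nM.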

Compound 4, half-maximal effective concentration: 39.8 nM
Compound 4: the middle estimate sits 2.5-fold (0.40 log units) above what was measured, within the range that was stated.
By their numbers in this assay, from the lowest: compound 2; then compound 4; then compound 3.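

At this place on the six-membered aromatic ring, a second entering ring with 2 hetero atoms also raises the number in this assay (a 40-fold higher number from compound 2 to compound 4 (1.60 log units; beyond the scatter)), so the large rise no longer rests on compound 3 alone. The size of the rise still depends on which ring enters, as the two rings with 2 hetero atoms are separated by a step beyond the scatter (a 4.0-fold lower number from compound 3 to compound 4 (0.60 log units; beyond the scatter)). Compound 2, with thiophen-2-yl, keeps the lowest number among the three compounds that carry a five-membered aromatic ring here.

Open, going by these compounds, is whether furan-2-yl, an unsubstituted phenyl ring or a primary amine at this place would stay close to compound 2 or follow compound 3 and compound 4. No measurement shown here accounts for the differences among these rings.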